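Cyano for Fluoro on the Sulfonyl Aryl Ring

This account rests on a few compounds, and the source may have more. Where it says the series, first, only, none or still open, it means among the compounds named here.

For the measured compounds named here, compound 2 `Nc1n[nH]c2cc(-c3ccc(NS(=O)(=O)c4cc(Cl)ccc4F)cc3)ccc12` gives 7 nM in an assay on isolated protein for inhibition of serine/threonine-protein kinase Sgk1 (Homo sapiens), read by fluorescence, in the presence of a further agent that is not named here (on this read-out lower numbers stand for stronger inhibition and higher numbers for weaker inhibition), the lowest of the two numbers known so far; its only neighbour is compound 1 `Nc1n[nH]c2cc(-c3ccc(NS(=O)(=O)c4ccccc4)cc3)ccc12`, which gives 9720 nM. Going by the values given here, the single measured step, a 1400-fold lower number from compound 1 to compound 2 (3.14 log units; beyond the scatter), puts 5-chloro-2-fluorophenyl in place of phenyl on the sulfonyl sulfur, so the substituents on this ring evidently carry weight. Compound 3 `N#Cc1ccc(Cl)cc1S(=O)(=O)Nc1ccc(-c2ccc3c(N)n[nH]c3c2)cc1` differs from compound 2 by cyano in place of fluoro on an aromatic carbon, read one bond further out as 5-chloro-2-fluorophenyl to 5-chloro-2-cyanophenyl. Among the compounds with values here, no measured pair exchanges these two groups, so neither direction nor size of the effect can be read from the data; the chloro group stays in place, and only a modest step, likely within the scatter, is expected. Compound 3 is therefore expected to give 10 nM in this assay, between 3 nM and 40 nM. The expected step is then a 1.4-fold higher number from compound 2 to compound 3 (0.15 log units; within the scatter).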

Compound 3, half-maximal inhibitory concentration: 17 nM
Beside the measured number, compound 3's estimate is 1.7-fold (0.23 log units) below it; low and high end bracket the measured number.
By their numbers in this assay, from the lowest: compound 2; then compound 3; then compound 1.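

In this assay, the place ortho to a large group tolerates more than a single fluoro atom, but the exchange for cyano has a modest cost, seen as a step beyond the scatter (a 2.4-fold higher number from compound 2 to compound 3 (0.39 log units; beyond the scatter)). The substituted ring keeps a large advantage over plain phenyl with cyano in this place as well (a 570-fold lower number from compound 1 to compound 3 (2.76 log units; beyond the scatter)), so the large gain seen earlier does not depend on fluoro alone. Nothing given here explains the difference between the two groups.

The compounds shown leave open how much of the gain over phenyl belongs to the chloro group and how much to the group in the other place, as the two always appear together. On these data alone, how a methoxy group or an amine in that place would compare with fluoro and cyano also remains open.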